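A Trifluoromethyl Swap at the Assay Limit

The compounds below may be only part of what the source reports. "The series", "measured", "known", "first", "only" and "open" are said of these compounds alone.

Compound 1, `C=C[C@@](C)(/C=C/c1ccc(OC)cc1)CCC=C(C)C`, carries a methoxy group on the shared core. Compound 2, `C=C[C@@](C)(/C=C/c1ccc(Nc2ccc(OC)cc2)cc1)CCC=C(C)C`, has (4-methoxyphenyl)amino there instead, and compound 3, `C=C[C@@](C)(/C=C/c1ccc(Nc2cc(F)cc(F)c2)cc1)CCC=C(C)C`, has (3,5-difluorophenyl)amino.

In a functional assay on Raji cells (Homo sapiens) for cytotoxicity, with a stated time of 72 h (on this read-out lower numbers stand for an effect already at smaller amounts and higher numbers for an effect only at larger amounts of compound), compound 2 gives > 26000 nM, which is a limit and not a number. Compound 1 gives > 26000 nM, also a limit. Compound 3 gives > 26000 nM, again a limit. Compound 2 therefore has no number of its own and shares its limit with both neighbours.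

Compound 4, `C=C[C@@](C)(/C=C/c1ccc(Nc2ccc(C(F)(F)F)cc2)cc1)CCC=C(C)C`, has trifluoromethyl in place of methoxy on an aromatic carbon, para to a large group: trifluoromethyl in place of methoxy on an aromatic carbon.

The nearest measured change is a step that the two limits leave unreadable from compound 2 to compound 3, which also alters the aromatic ring on the nitrogen. Two further changes are a step that the two limits leave unreadable from compound 1 to compound 2 and a step that the two limits leave unreadable from compound 1 to compound 3. On these data alone, all three sizes stay unknown due to the limit of > 26000 nM in this assay, at which 3 of the 3 values shown sit. None of these changes produced a number in this assay, so no step beyond the scatter is expected, and the data support no direction. The expected step is a step that the limit leaves unreadable from compound 2 to compound 4. The estimate for compound 4 is 30000 nM, with an expected range from 12000 nM to 80000 nM, and the assay will most likely report only a limit.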

Compound 4, half-maximal effective concentration: > 26000 nM
Compound 4: no number, only a limit; the forecaster's own chance of this, stated with the estimate: 85%; the middle value does not contradict the limit.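

In this assay compound 4 gives > 26000 nM, which is a limit and not a number, so the step from compound 2 to compound 4 cannot be read. The compounds shown leave open how compound 1, compound 2, compound 3 and compound 4 truly compare with one another, for one reason: the limit of > 26000 nM in this assay, at which 4 of the 4 values shown sit.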